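The source may report more compounds than this note shows. Statements on the series, on what has been measured and on what is new or still open speak of the compounds shown alone.

The measured compounds:
Compound 1 `Cc1cc(C#N)cc(C)c1Oc1ccnc(S(=O)(=O)CC(=O)Nc2ccccc2)n1`: 29300 nM
Compound 2 `Cc1cccc(NC(=O)CS(=O)(=O)c2nccc(Oc3c(C)cc(C#N)cc3C)n2)c1`: 25700 nM
Compound 3 `Cc1cc(C#N)cc(C)c1Oc1ccnc(S(=O)(=O)CC(=O)Nc2ccc(Br)cc2)n1`: 15600 nM

In an ADME assay on MT4 cells (Homo sapiens) for cytotoxicity, read by MTT assay, with a stated time of 4 days (a higher number here means that more compound is tolerated, a lower number that less compound is tolerated), compound 2 gives 25700 nM, the second highest of the three numbers. Its nearest neighbour is compound 1, separated by a 1.1-fold lower number from compound 1 to compound 2 (0.06 log units; within the scatter), and the furthest is compound 3, separated by a 1.6-fold lower number from compound 2 to compound 3 (0.22 log units; within the scatter). Compound 4 `Cc1cc(C#N)cc(C)c1Oc1ccnc(S(=O)(=O)CC(=O)Nc2ccc(C#N)cc2)n1` differs from compound 2 by 4-cyanophenyl in place of 3-methylphenyl on an amide-type nitrogen. Going by the values given here, no measured step places a nitrile on that ring. Among the compounds with values here, the steps that bear on the change are the exchange of the same 3-methylphenyl, a 1.6-fold lower number from compound 2 to compound 3 (0.22 log units; within the scatter), and the bromo substitution, a 1.9-fold lower number from compound 1 to compound 3 (0.27 log units; within the scatter), both within the scatter. The expected step is therefore small, a 1.3-fold lower number from compound 2 to compound 4 (0.11 log units; within the scatter). Compound 4 is estimated at 20000 nM, in the range 9000 nM to 45000 nM.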

Compound 4, half-maximal cytotoxic concentration: >= 6010 nM
Compound 4: only a limit was reported; the forecaster's own chance of this, stated with the estimate: 5%; the middle value does not contradict the limit.
By their numbers in this assay, from the lowest: compounds 3, 2 and 1 (each within the scatter of the next).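

Compound 4 is reported only as a limit, >= 6010 nM, so its steps from compound 1, compound 2 and compound 3 cannot be read. The compounds shown leave open where compound 4 actually lies relative to those three.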